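Straightening the Chain on the Carbonyl Oxygen: Compound 3 to Compound 4

The source may hold more compounds than are shown below. What is called first, only, known or untested is meant among the compounds shown, and "the series" means these compounds.

Of the compounds shown here, three sharing one core have been tested in a functional assay on MCF7 cells (Homo sapiens) for cytotoxicity, read by MTT assay, with a stated time of 72 h; a higher number here means a weaker inhibitor of growth, a lower number a stronger inhibitor of growth. Compound 1 `N#C[Se]c1ccc(NC(=O)OCc2ccccc2)cc1` gives 38800 nM, compound 2 `CCOC(=O)Nc1ccc([Se]C#N)cc1` gives 36700 nM, and compound 3 `CC(C)COC(=O)Nc1ccc([Se]C#N)cc1` gives 45500 nM, the highest of the three numbers, though each gap to it lies within the scatter. Compound 4 `CCCCOC(=O)Nc1ccc([Se]C#N)cc1` differs from compound 3 by propyl in place of isopropyl on a saturated chain carbon bound to an oxygen next to a carbonyl group. The earlier steps shown here at this same place, a 1.1-fold lower number from compound 1 to compound 2 (0.02 log units; within the scatter), a 1.2-fold higher number from compound 1 to compound 3 (0.07 log units; within the scatter) and a 1.2-fold higher number from compound 2 to compound 3 (0.09 log units; within the scatter), all stayed within the scatter, so swapping the group on this carbon has not moved the number so far. The step of a 1.1-fold lower number from compound 3 to compound 4 (0.03 log units; within the scatter) is therefore expected to stay within the scatter as well. Compound 4 is estimated at 42000 nM, with a range from 21000 nM to 84000 nM.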

Compound 4, concentration for total growth inhibition: 20200 nM
Beside the measured number, compound 4's estimate is 2.1-fold (0.32 log units) above it; the whole stated range lies above it.
By their numbers in this assay, from the lowest: compounds 4, 2, 1 and 3 (each within the scatter of the next, the first and the last beyond it).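

In this assay, going by these compounds alone, the step of a 2.3-fold lower number from compound 3 to compound 4 (0.35 log units; beyond the scatter) lies beyond the scatter, unlike the earlier steps on this saturated chain carbon, so this place can respond to a change, though only modestly. The change is isopropyl to propyl, the same atoms joined differently, yet the step of a 1.8-fold lower number from compound 2 to compound 4 (0.26 log units; within the scatter) and the step of a 1.9-fold lower number from compound 1 to compound 4 (0.28 log units; within the scatter) both stay within the scatter, so compound 4 stands clear of compound 3 alone. Nothing available here accounts for this difference.

As far as these compounds go, what a longer chain such as hexyl would give remains open. So does the effect of an amine or a carboxylic acid at the end of the chain.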